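Stereoisomer pair on the sulfone-benzothiazole amide series

This account rests on a few compounds, and the source may have more. Where it says the series, first, only, none or still open, it means among the compounds named here.

Two compounds of the series have numbers in an assay on cells for displacement of a labelled ligand from growth hormone secretagogue receptor type 1 (Homo sapiens), with a stated time of 60 min; a lower number here means a stronger inhibitor, a higher number a weaker inhibitor. Compound 1, `CCOc1cc(Cl)c(C(=O)NC(=O)Nc2nc3ccc(S(=O)(=O)C4CCN(C)CC4)cc3s2)cc1-n1cccn1`, carries an acylurea linker and a pyrazole on the aryl ring; in this assay compound 1 gives 8 nM. Compound 2, `CCOc1cc(Cl)c(C(=O)Nc2nc3ccc(S(=O)(=O)CCCN4CCN(C)CC4)cc3s2)cc1N1C[C@H](C)O[C@@H](C)C1`, carries a plain amide, a propyl-linked methylpiperazine on the sulfone and a dimethylmorpholine on the aryl ring; in this assay compound 2 gives 10000 nM. Compound 2 stands at the highest of the two numbers, the gap to compound 1 lying far beyond the scatter, but the two compounds differ in several places at once, so no single change can be read from the pair.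

Compound 3, `CCOc1cc(Cl)c(C(=O)Nc2nc3ccc(S(=O)(=O)CCCN4CCN(C)CC4)cc3s2)cc1N1C[C@@H](C)O[C@@H](C)C1`, is the remaining case: the two compounds have the same atoms and bonds and differ only in configuration as drawn: 1 of 2 stereo elements differ; a stereocentre at a saturated ring carbon is drawn S in compound 2 and R in compound 3. Among the measured compounds shown here, no measured pair isolates a configuration change, so no step size can be taken from the data. The expectation is that the number stays high, with a step of a 1.7-fold lower number from compound 2 to compound 3 (0.22 log units; within the scatter) that may not exceed the scatter, and the value for compound 3 is estimated at 6000 nM within a range of 1500 nM to 10000 nM.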

Compound 3, half-maximal inhibitory concentration in the growth hormone secretagogue receptor type 1 assay: 27000 nM
The estimate for compound 3 lay 4.5-fold (0.65 log units) below the measured number; measured number above the stated range.
By their numbers in the growth hormone secretagogue receptor type 1 assay, from the lowest: compound 1; then compound 2; then compound 3.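

Compounds 2 and 3 give the series its first reading of a single change, a stereocentre at a saturated ring carbon of the dimethylmorpholine drawn S in compound 2 and R in compound 3. In the growth hormone secretagogue receptor type 1 assay that change gives a 2.7-fold higher number from compound 2 to compound 3 (0.43 log units; beyond the scatter), a modest step that shows this stereocentre has a measurable bearing on the number, and it can be assigned to configuration alone because nothing else separates the pair: the fact that compounds 2 and 3 differ only in the configuration as drawn. In a physicochemical assay for lipophilicity, at pH 7.4 (on this read-out higher numbers stand for higher lipophilicity and lower numbers for lower lipophilicity), compound 2 gives 3 and compound 3 gives 2.7, and the same pair gives a number 0.30 log units lower from compound 2 to compound 3 (within the scatter), so that read-out does not separate the two isomers.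

From the compounds shown here alone, the steps from compound 1 to compounds 2 and 3 cannot be read, as the acylurea linker, the group on the sulfone and the group on the aryl ring all change together, so it remains open which of these carries the large gap in the numbers. Also open, going by these compounds, is how the number would respond to a morpholine without its two methyl groups or a piperidine on the aryl ring, and whether this stereocentre matters as much on a compound carrying the acylurea linker.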